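A Furan for a Phenyl on the Amide Carbonyl

The source may hold more compounds than are shown below. What is called first, only, known or untested is meant among the compounds shown, and "the series" means these compounds.

Measured compounds:
compound 1 `CCN1CCN(c2cc(C)c3cc(NC(=O)c4ccccc4)ccc3n2)CC1` — 14200 nM
compound 2 `CCNc1cc(C)c2cc(NC(=O)c3ccc(Cl)c(Cl)c3)ccc2n1` — 48600 nM
compound 3 `Cc1cc(N(C)C)nc2ccc(NC(=O)c3ccc(Cl)c(Cl)c3)cc12` — 33300 nM

The three compounds share a core and differ in the amine attached to the aromatic carbon and in the acyl group of the amide. In a functional assay on MCF7 cells (Homo sapiens) for antiproliferative activity, read by MTT assay, with a stated time of 72 h (a lower number here means a stronger inhibitor, a higher number a weaker inhibitor), compound 1 gives 14200 nM, the lowest of the three numbers. Compound 3 gives 33300 nM and compound 2 gives 48600 nM; both gaps to compound 1 lie beyond the scatter, so compound 1 is the strongest inhibitor among them. Among the measured compounds shown here, the one step between compounds that differ in a single place is a 1.5-fold lower number from compound 2 to compound 3 (0.16 log units; within the scatter); it touches the amine, not the acyl group.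

Compound 4 `CCN1CCN(c2cc(C)c3cc(NC(=O)c4ccco4)ccc3n2)CC1` differs from compound 1 in one place: furan-2-yl in place of phenyl on a carbonyl carbon. For the measured compounds named here, no measured step bears on this change, since nothing among the three compounds varies the acyl group alone, and the one measured step concerns another part of the molecule. An expectation can therefore rest only on the value of compound 1. Compound 4 is estimated at 18000 nM, with a range of 7000 nM to 45000 nM. The step of a 1.3-fold higher number from compound 1 to compound 4 (0.10 log units; within the scatter) is expected to stay within the scatter or lean slightly toward a weaker inhibitor.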

Compound 4, half-maximal inhibitory concentration: 41200 nM
Estimate against measurement, compound 4: 2.3-fold (0.36 log units) below; measured number inside the range.
By their numbers in this assay, from the lowest: compound 1; then compounds 3, 4 and 2 (each within the scatter of the next).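

In this assay the acyl group of the amide proves to be a position that responds: exchanging phenyl for furan-2-yl on the carbonyl carbon, with the amine and the shared core held fixed, gives a 2.9-fold higher number from compound 1 to compound 4 (0.46 log units; beyond the scatter) and moves toward a weaker inhibitor. Among the compounds shown here, the earlier compounds could not show this, since their only single-place step concerned the amine on the aromatic carbon and stayed within the scatter, whereas this first step at the carbonyl carbon lies beyond it. The change replaces a six-membered aromatic ring of carbon only with a five-membered aromatic ring holding one hetero atom and one hydrogen-bond acceptor, but nothing available indicates which of these differences, if any, accounts for the step.

Going by these compounds, it remains open whether the step belongs to the oxygen of the furan-2-yl group or to the five-membered ring as such, a question that a thiophen-2-yl group on the same carbonyl carbon would address. Also open is how a 3,4-dichlorobenzoyl group would read on the amine of compound 1, as the compounds shown never vary that acyl group alone.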